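Adding a tert-butyl group: what solubility to expect

The source may report more compounds than this note shows. Statements on the series, on what has been measured and on what is new or still open speak of the compounds shown alone.

Measured so far:
compound 1 `COc1ccc(Oc2ccc3c(NCCCNCc4cccc(OC)c4O)ccnc3c2)cc1` gives 14500 nM
compound 2 `COc1ccc(F)cc1CNCCCNc1ccnc2cc(Oc3ccc(C(C)(C)C)cc3)ccc12` gives 14500 nM
compound 3 `COc1cccc(CNCCCNc2ccnc3cc(Oc4ccccc4)ccc23)c1O` gives 14500 nM

The three measured compounds were all tested in a physicochemical assay for solubility, with a stated time of 18 h, at pH 7.4; a higher number here means a more soluble compound, a lower number a less soluble compound. Compound 3 stands level with compound 1 and compound 2 at the digits shown; the three values are within the scatter of one another, so no order among them can be claimed.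

One step between measured compounds is known. Going from compound 1 to compound 3 replaces a methoxy group on an aromatic carbon with hydrogen, and the result is no change at the digits printed from compound 1 to compound 3 (within the scatter). Among the measured compounds shown here, compound 2 also carries a tert-butyl group on its phenoxy ring, and its value is the same as that of compound 3, but the two compounds differ in more than one place, so no single step can be drawn between them.

The compound still to be measured is compound 4 `COc1cccc(CNCCCNc2ccnc3cc(Oc4ccc(C(C)(C)C)cc4)ccc23)c1O`. It differs from compound 3 by tert-butyl in place of hydrogen on an aromatic carbon. For the measured compounds named here, the one known step shows no change beyond the scatter, and compound 2, which already carries this group, sits at the same value. The expected step from compound 3 to compound 4 is therefore a 1.0-fold lower number from compound 3 to compound 4 (0.02 log units; within the scatter), no change beyond the scatter. Compound 4 is estimated at 14000 nM, with a range from 7000 nM to 20000 nM.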

Compound 4, solubility: 14500 nM
Compound 4: middle estimate off by 1.0-fold (0.02 log units), on the low side; measured number inside the range.
By their numbers in this assay, from the lowest: compounds 1, 2, 3 and 4 (each within the scatter of the next).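

In this assay, tert-butyl on this aromatic carbon, turning phenoxy into 4-(tert-butyl)phenoxy, gives no change at the digits printed from compound 3 to compound 4 (within the scatter), so the earlier hydrogen-for-methoxy step now has a counterpart with a much larger group of 4 heavy atoms. The direct swap at the same aromatic carbon, tert-butyl in place of methoxy, gives no change at the digits printed from compound 1 to compound 4 (within the scatter), so hydrogen, methoxy and tert-butyl can no longer be told apart here in this assay. With tert-butyl present, a change at the other end of the molecule, 2-hydroxy-3-methoxyphenyl in place of 5-fluoro-2-methoxyphenyl, gives no change at the digits printed from compound 2 to compound 4 (within the scatter), and no outside measurement offers an explanation for these matching numbers.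

Among the compounds shown here, every step so far shows no change, so it remains open whether any substituent on this aromatic carbon can shift the number in this assay, for example a carboxylic acid or an amine. As far as these compounds go, it is equally open whether a longer chain between the two nitrogens of the linker, or a different group in place of the substituted phenyl at the far end, would give a different value.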